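A few compounds are considered here, and "the series" means these few. Any claim that something is new, unique, unknown or untested is made for them only; others in the source may bear on it.

Compound 2 `Cc1ccc(C)c(-n2nncc2CN2C(=O)C3(C(C#N)=C(N)Oc4c(N)cc5nc6ccccc6nc5c43)c3ccccc32)c1` stands in an ADME assay on HUVEC cells (Homo sapiens) for antiproliferative activity, read by MTT assay, with a stated time of 48 h (on this read-out higher numbers stand for weaker inhibition and lower numbers for stronger inhibition), at a limit of the assay, > 50000 nM. Compound 1 `CCc1ccccc1-n1nncc1CN1C(=O)C2(C(C#N)=C(N)Oc3c(N)cc4nc5ccccc5nc4c32)c2ccccc21` also reaches only a limit in this assay, > 50000 nM. The step that the two limits leave unreadable from compound 1 to compound 2 therefore has no readable size, as both values sit at the limit of > 50000 nM in this assay, at which 2 of the 2 values shown sit. Compound 3 `N#CC1=C(N)Oc2c(N)cc3nc4ccccc4nc3c2C12C(=O)N(Cc1cnnn1-c1c(F)cccc1F)c1ccccc12` differs from compound 2 by 2,6-difluorophenyl in place of 2,5-dimethylphenyl on an aromatic nitrogen. Going by the values given here, the only measured step that bears on a change at this aromatic nitrogen is the one between the two limits, and it gives no size and no direction. Compound 2 itself shows nothing but a limit in this assay. On that footing compound 3 is expected to remain at the same limit, with the step that the limit leaves unreadable from compound 2 to compound 3 estimated as nothing beyond the scatter. The value of compound 3 in this assay is thus estimated at 60000 nM, with a range from 20000 nM to 200000 nM.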

Compound 3, half-maximal inhibitory concentration: > 50000 nM
Compound 3: only a limit was reported; the forecaster's own chance of this, stated with the estimate: 85%; the middle value lies beyond the limit too.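

In this assay, going by these compounds alone, no step among compound 1, compound 2 and compound 3 can be read, as all three values are limits: the limit of > 50000 nM in this assay, at which 3 of the 3 values shown sit. These compounds leave open whether any group on this aromatic nitrogen changes the antiproliferative activity, and what true value lies behind each limit.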